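The source may hold more compounds than are shown below. What is called first, only, known or untested is meant among the compounds shown, and "the series" means these compounds.

Series notes. Going by the values given here, compound 1 `COc1cc2c(cc1OC)C(=O)C(CC1CCN(C(=S)Nc3ccc(C)cc3)CC1)C2` is the only member of the set with a number so far: in a functional assay on the whole organism (strain Swiss albino) with Mus musculus as the target, with a stated time of 4 h (on this read-out lower numbers stand for an effect already at smaller amounts and higher numbers for an effect only at larger amounts of compound), compound 1 gives 300 mg/kg. Compound 2 `COc1cc2c(cc1OC)C(=O)C(CC1CCN(C(=S)Nc3cccc([N+](=O)[O-])c3)CC1)C2` carries no result; in this assay compound 2 stands as "not determined" (no result reported). Among the compounds with values here, because no pair of measured compounds differs in one place, nothing here shows how large a single structural change moves the read-out, and the scale of the series remains unset. The next compound, compound 3 `CCCNC(=S)N1CCC(CC2Cc3cc(OC)c(OC)cc3C2=O)CC1`, differs from compound 1 in one place: propyl in place of 4-methylphenyl on an amide-type nitrogen. Within the data shown here, with one number and no measured step to set the scale, the expected step is no change at the digits printed from compound 1 to compound 3 (within the scatter), no movement beyond the ordinary scatter, in neither direction. On that basis compound 3 is estimated to give 300 mg/kg in this assay, with 100 mg/kg to 900 mg/kg as the expected span, the wide span reflecting the single reference point.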

Compound 3, minimum effective dose: 300 mg/kg
Estimate against measurement, compound 3: no gap at the digits printed; the range from low to high includes it.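

Going by these compounds alone, the first measured step at this position comes from the substituent on the amide-type nitrogen whose other neighbour is the thiocarbonyl carbon: in this assay, propyl in place of 4-methylphenyl gives no change at the digits printed from compound 1 to compound 3 (within the scatter). For this single pair, the six-membered aromatic ring of carbon only can therefore leave and a smaller open chain can enter without the read-out moving beyond the usual scatter. No available measurement bears on why the read-out holds across this change.

As far as these compounds go, it remains open whether a benzyl group, a longer alkyl chain or a chain ending in an amine at this nitrogen would also leave the read-out in place, or whether any group here moves it beyond the scatter. Also open, from the compounds shown here alone, is whether a carbonyl in place of the thiocarbonyl would change the read-out.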